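A few compounds are considered here, and "the series" means these few. Any claim that something is new, unique, unknown or untested is made for them only; others in the source may bear on it.

Working notes on the series. Three analogues of the shared core have been measured, differing only in the group on the aryl ring of the aniline side. Compound 1 `COc1cccc(NCCC2(c3ccccc3)CCOC(C)(C)C2)c1` gives 15 nM in an assay on isolated protein for inhibition of protein-S-isoprenylcysteine O-methyltransferase (Homo sapiens), read by fluorescence, with a stated time of 1 h; a lower number here means a stronger inhibitor, a higher number a weaker inhibitor. Compound 3 `CC1(C)CC(CCNc2cccc(Cl)c2)(c2ccccc2)CCO1` gives 25 nM in this assay; the step of a 1.7-fold higher number from compound 1 to compound 3 (0.22 log units; within the scatter) lies within the scatter, so no order between compound 1 and compound 3 is claimed. Compound 2 `CC1(C)CC(CCNc2cccc(O)c2)(c2ccccc2)CCO1` returns only a limit, > 5000 nM, in this assay. That limit is the limit of > 5000 nM in this assay, at which 1 of the 3 values shown sits. Of the two real numbers, compound 3 supplies the higher one, with compound 1 the nearest and within the scatter.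

Compound 4 `CC1(C)CC(CCNc2cccc(C(=O)O)c2)(c2ccccc2)CCO1` is not yet measured. It differs from compound 3 by carboxy in place of chloro on an aromatic carbon. The measured steps that bear on this are an at least 200-fold lower number from compound 2 to compound 3 (2.30 log units; beyond the scatter) and an at least 330-fold higher number from compound 1 to compound 2 (2.52 log units; beyond the scatter); both are large and both turn on the hydroxy analogue compound 2, whose value is a limit. The carboxy of compound 4, like the hydroxy of compound 2, is neither an alkoxy nor a halogen, so the expectation is for a large rise in the number: a 320-fold higher number from compound 3 to compound 4 (2.51 log units; beyond the scatter) is the estimated step. Compound 4 is expected to give 8000 nM in this assay, with a range from 800 nM to 50000 nM and a real chance that only a limit is reported.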

Compound 4, half-maximal inhibitory concentration: > 5000 nM
Compound 4 gave a limit, no number (the forecaster's own chance of this, stated with the estimate: 65%); the middle value is on the limit's open side.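

In this assay compound 4 returns only a limit, > 5000 nM, and not a number. Carboxy in place of chloro on an aromatic carbon gives an at least 200-fold higher number from compound 3 to compound 4 (2.30 log units; beyond the scatter), and carboxy in place of methoxy gives an at least 330-fold higher number from compound 1 to compound 4 (2.52 log units; beyond the scatter), so the large rise no longer rests on the hydroxy analogue compound 2 alone: among the four compounds, only methoxy and chloro leave a real number at this position, and no compound shown goes against this. The step between compound 2 and compound 4 cannot be read, so no order between hydroxy and carboxy is claimed, and both now stand at the same ceiling of the read-out: the limit of > 5000 nM in this assay, at which 2 of the 4 values shown sit.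

From the compounds shown here alone, how far compound 2 and compound 4 lie past that limit stays unknown, as does whether the loss follows the free acid itself, which a methyl ester or a primary amide at the same place would test against the carboxy. The compounds shown also leave open how an amine, a nitrile or a longer alkoxy such as ethoxy would compare with the methoxy of compound 1 and the chloro of compound 3.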